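The source may hold more compounds than are shown below. What is called first, only, known or untested is meant among the compounds shown, and "the series" means these compounds.

Measured so far in an assay on HEK293 cells for activation of Kir3.1/Kir3.2 (Homo sapiens), read by thallium flux; a lower number here means that less compound is needed, a higher number that more compound is needed for the effect:

compound 1, `O=C(Cn1nnc(-c2ccccc2)n1)NC1CC2CCC1C2`, gives 1980 nM
compound 2, `Cc1cc(NC(=O)Cn2nnc(-c3ccccc3)n2)n(C(C)C)n1`, gives 556 nM
compound 3, `Cc1cc(NC(=O)Cn2nnc(-c3ccccn3)n2)n(C2CCCCC2)n1`, gives 14600 nM

Compound 3 therefore stands at the highest number of the three, meaning that the most compound is needed for the effect. Its nearest neighbour is compound 1, whose number is lower by a margin beyond the usual scatter, and compound 2 lies further still below it. No two of these compounds differ in only one place, so none of these gaps can be tied to a single change.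

Compound 4, `Cc1cc(NC(=O)Cn2nnc(-c3ccnc(F)c3)n2)n(C2CCCCC2)n1`, is the not yet measured neighbour of compound 3. Within the data shown here, the only change is 2-fluoropyridin-4-yl in place of pyridin-2-yl on an aromatic carbon of the shared core. Among the measured compounds shown here, with no measured step of this kind available, the direction is uncertain. Compound 2, which carries a plain phenyl in this position, gives 556 nM, but it also differs elsewhere, so it offers only a loose hint that a group other than pyridin-2-yl might be tolerated better. A moderate step downward from compound 3 to compound 4 is expected, a 3.7-fold lower number from compound 3 to compound 4 (0.56 log units; beyond the scatter), though a result within the scatter would not surprise. For compound 4 the estimate in this assay is 4000 nM, with a range from 800 nM to 20000 nM.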

Compound 4, half-maximal effective concentration: 441 nM
For compound 4 the middle estimate is 9.1-fold (0.96 log units) above the measured one; measured number outside the range, below it.
By their numbers in this assay, from the lowest: compounds 4 and 2 (each within the scatter of the next); then compound 1; then compound 3.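

In this assay, among these compounds, putting 2-fluoropyridin-4-yl in place of pyridin-2-yl on the aromatic carbon of the five-membered aromatic ring with 4 nitrogen gives a 33-fold lower number from compound 3 to compound 4 (1.52 log units; beyond the scatter) and is the first change here that can be tied to a single place. It shows that the number in this series can move by a large step through this position alone, even though both groups are six-membered aromatic rings with one hetero atom, carry the same count of hydrogen-bond acceptors and have no net charge. No measurement at hand bears on why the number fell so far.

The step joins two differences, the added fluorine and the change from a pyridin-2-yl to a pyridin-4-yl framework, and the compounds shown cannot separate them, since a plain pyridin-4-yl on the same core is not among them. From the compounds shown here alone, it also remains open whether the fluorine could give way to another group on that ring, such as chlorine, a methoxy group or an amine, with the number staying as low.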